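The source may hold more compounds than are shown below. What is called first, only, known or untested is meant among the compounds shown, and "the series" means these compounds.

Working notes on the series. In a functional assay, with a stated time of 150 min (on this read-out higher numbers stand for weaker inhibition and lower numbers for stronger inhibition), compound 1 `CSc1nc(-c2ccc(N(C)C)cc2)c(C#N)c(=O)n1C` gives 93 ug/mL, compound 3 `Cn1c(NN)nc(-c2ccccc2F)c(C#N)c1=O` gives 60 ug/mL, and compound 2 `CCOC(=O)c1cnn(-c2nc(-c3ccccc3O)c(C#N)c(=O)n2C)c1N` gives 64 ug/mL; the three numbers lie within the usual scatter of one another, so on this assay compound 2 sits in the same band as compounds 1 and 3. The shared core is kept throughout. Compound 4 `CCOC(=O)c1cnn(-c2nc(-c3cccc(OC)c3OC)c(C#N)c(=O)n2C)c1N` differs from compound 2 in one place: 2,3-dimethoxyphenyl in place of 2-hydroxyphenyl on an aromatic carbon. Among the compounds with values here, no measured pair on this assay isolates such a change, so there is no step to rest on. With the hydroxyl donor gone and two methoxy acceptors in its place, no shift beyond the scatter is expected, and the step from compound 2 to compound 4 is estimated at a 1.1-fold higher number from compound 2 to compound 4 (0.04 log units; within the scatter). Compound 4 is accordingly expected to give about 70 ug/mL in this assay, with a likely range of 30 ug/mL to 160 ug/mL.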

Compound 4, half-maximal inhibitory concentration: 69 ug/mL
Estimate against measurement, compound 4: 1.0-fold (0.01 log units) above, within the range that was stated.
By their numbers in this assay, from the lowest: compounds 3, 2, 4 and 1 (each within the scatter of the next).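

Replacing 2-hydroxyphenyl with 2,3-dimethoxyphenyl on this aromatic carbon gives a 1.1-fold higher number from compound 2 to compound 4 (0.03 log units; within the scatter) in this assay, the first step measured at this position. In this one pair, going from 1 hydrogen-bond donor to 0 leaves the read-out within the scatter. No available data bear on the reason for this result.

On these data alone, whether an amine or a carboxylic acid on the phenyl ring would move the number beyond the scatter remains open. So does whether the same change would read alike with the groups of compound 1 or compound 3 elsewhere on the shared core.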